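Cyclopentyl to cyclopropyl on the ring amine: working notes

A few compounds are considered here, and "the series" means these few. Any claim that something is new, unique, unknown or untested is made for them only; others in the source may bear on it.

Measured so far:
Compound 1 `CCCCNc1nc(-c2ccccc2)nc2c1nnn2Cc1ccccc1C(F)(F)F`; in an assay on isolated protein for binding affinity to adenosine receptor A1 (Bos taurus) (a lower number here means a stronger inhibitor, a higher number a weaker inhibitor), compound 1 gives 6500000 nM.
Compound 2 `FC(F)(F)c1ccccc1Cn1nnc2c(NC3CCCC3)nc(-c3ccccc3)nc21`; in this assay compound 2 gives 600000 nM.

Going by the values given here, compound 2 holds the lowest of the two numbers known, and the only step known in the set is an 11-fold lower number from compound 1 to compound 2 (1.03 log units; beyond the scatter), a large one toward the five-membered ring. Compound 3 `FC(F)(F)c1ccccc1Cn1nnc2c(NC3CC3)nc(-c3ccccc3)nc21` differs from compound 2 by cyclopropyl in place of cyclopentyl on a nitrogen on an aromatic ring. Among the compounds with values here, only the step from compound 1 to compound 2 bears on this change, and it runs in the opposite sense: there the ring replaced a chain and the number fell sharply. Going from the five-membered to the three-membered ring, the expectation is a return toward a higher number, with the step estimated as a 5.0-fold higher number from compound 2 to compound 3 (0.70 log units; beyond the scatter). The estimate for compound 3 in this assay is 3000000 nM, with a range from 800000 nM to 12000000 nM.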

Compound 3, inhibition constant: 7800000 nM
Compound 3: the middle estimate sits 2.6-fold (0.41 log units) below what was measured; the range from low to high includes it.
By their numbers in this assay, from the lowest: compound 2; then compounds 1 and 3 (each within the scatter of the next).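

In this assay, cyclopentyl now stands apart from both other groups on this nitrogen: the change to cyclopropyl is a large step back (a 13-fold higher number from compound 2 to compound 3 (1.11 log units; beyond the scatter)), so a carbon ring here does not by itself go with the lower number. Cyclopropyl and butyl are not told apart (a 1.2-fold higher number from compound 1 to compound 3 (0.08 log units; within the scatter)), which leaves compound 2 alone with the lowest number in the set and shows that the earlier gain from butyl to cyclopentyl does not carry over to the three-membered ring. No measurement at hand offers an explanation for why the five-membered ring differs from the other two groups.

Open, on these data alone, is whether cyclobutyl or cyclohexyl on the same nitrogen would follow cyclopentyl or cyclopropyl. Also open, as far as these compounds go, is whether an isopropyl chain or a tetrahydropyranyl ring would keep the lower number, and whether the same order holds with the trifluoromethyl group replaced by a methoxy group.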